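Cyano in Place of Butyl: An Expectation for Compound 3

The source may hold more compounds than are shown below. What is called first, only, known or untested is meant among the compounds shown, and "the series" means these compounds.

Measured so far:
compound 1, `CCCCc1ccc(C(=O)Nc2cc(C(=O)O)cc(C(=O)O)c2)cc1`, gives 91.9 mg/kg
compound 2, `O=C(O)c1cc(NC(=O)c2ccc(Cl)cc2Cl)cc(C(=O)O)c1`, gives 103 mg/kg

In a functional assay on the whole organism (stomach) with Rattus norvegicus as the target (a higher number here means that more compound is needed for the effect, a lower number that less compound is needed), compound 1 gives 91.9 mg/kg, the low end of the two numbers, yet compound 2 with 103 mg/kg lies within the scatter of it, so the two are not told apart. Compound 3, `N#Cc1ccc(C(=O)Nc2cc(C(=O)O)cc(C(=O)O)c2)cc1`, awaits measurement. It differs from compound 1 by cyano in place of butyl on an aromatic carbon. Among the compounds with values here, no measured pair shows such a change, so the expected step is a 1.3-fold higher number from compound 1 to compound 3 (0.10 log units; within the scatter), small, upward if anything, and likely within the scatter. Compound 3 is therefore estimated at 115 mg/kg, ranging from 50 mg/kg to 260 mg/kg.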

Compound 3, dose for 50% inhibition: 32.1 mg/kg
The estimate for compound 3 lay 3.6-fold (0.55 log units) above the measured number; measured number below the stated range.
By their numbers in this assay, from the lowest: compound 3; then compounds 1 and 2 (each within the scatter of the next).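

In this assay, within the data shown here, the aromatic carbon para to a large group turns out to respond to what it carries: cyano in place of butyl gives a 2.9-fold lower number from compound 1 to compound 3 (0.46 log units; beyond the scatter), a step the earlier compounds could not show. Butyl is therefore not needed there for the effect. Nothing measured explains why the number falls.

From the compounds shown here alone, whether the drop comes from cyano itself or simply from losing butyl remains open. So does how an amine, a carboxylic acid or a methyl group on that same carbon would compare with compound 3.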